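The source may hold more compounds than are shown below. What is called first, only, known or untested is meant among the compounds shown, and "the series" means these compounds.

Working notes on the series. Of the compounds shown here, two have so far been measured in an ADME assay on HepG2 cells (Homo sapiens) for cytotoxicity, read by resazurin assay, with a stated time of 48 h; on this read-out lower numbers stand for an effect already at smaller amounts and higher numbers for an effect only at larger amounts of compound. Compound 1 `O=C(Nc1ccc(F)c(-c2nc3ncc(-c4cc(F)ccc4F)cc3[nH]2)c1)N1CCCC1` gives in this assay only a limit of the assay, > 50000 nM, and not a number. Compound 2 `O=C(Nc1ccc(F)c(-c2nc3ncc(-c4ccc(F)nc4)cc3[nH]2)c1)N1CCCC1` likewise reaches in this assay only a limit of the assay, > 50000 nM. Going by the values given here, the step that the two limits leave unreadable from compound 1 to compound 2 cannot be read in either direction; both of its ends are limits, and the one piece of evidence in hand is the limit of > 50000 nM in this assay, at which 2 of the 2 values shown sit. Among the compounds with values here, compound 2 thus stands at the limit of this assay, as does the only other value known.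

Compound 3 `O=C(Nc1ccc(F)c(-c2nc3ncc(-c4cccnc4F)cc3[nH]2)c1)N1CCCC1` differs from compound 2 in one place only: 2-fluoropyridin-3-yl in place of 6-fluoropyridin-3-yl on an aromatic carbon. Within the data shown here, no measured step bears directly on this change, and the single recorded step gives no readable size. Nothing in the numbers in hand points to a step beyond the scatter in this assay. Compound 3 is expected to sit again at the limit of this assay, with an estimated value of 50000 nM, in a range from 20000 nM to 100000 nM. The step of a number no higher from compound 2 to compound 3 (the limit leaves the size open) is accordingly expected to be none beyond the scatter.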

Compound 3, half-maximal effective concentration: > 50000 nM
Compound 3: only a limit was reported (the forecaster's own chance of this, stated with the estimate: 85%); the middle value sits exactly at the limit.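

Compound 3, like compound 1 and compound 2, gives only a limit of the assay in this assay, so no step among these compounds can be read: the limit of > 50000 nM in this assay, at which 3 of the 3 values shown sit.

The compounds shown leave open where any of the three actually lies, and whether exchanging 2,5-difluorophenyl, 6-fluoropyridin-3-yl and 2-fluoropyridin-3-yl changes the read-out at all.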